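The source may report more compounds than this note shows. Statements on the series, on what has been measured and on what is new or still open speak of the compounds shown alone.

Measured compounds in a functional assay on cardiac atrium (Cavia porcellus); on this read-out lower numbers stand for an effect already at smaller amounts and higher numbers for an effect only at larger amounts of compound:
compound 1 `CCCSc1nc(N)c(N(CCC)CCC)c(OCC)n1` gives 150 nM
compound 2 `CCCSc1nc(NC(C)=O)c(N(CCC)CCC)c(=O)[nH]1` gives 280 nM

Compound 1 holds the lowest of the two numbers in this assay. The nearest is compound 2, whose value lies within the scatter of compound 1, so the two values show no order between them. Compound 1 and compound 2 differ in more than one place, and no single step can be read from the pair.

Compound 3 `CCCSc1nc(NC(C)=O)c(N(CCC)CCC)c(OCC)n1` is still to be measured in this assay. It differs from compound 1 by acetyl in place of hydrogen on a nitrogen on an aromatic ring; the same difference, cut one bond further out, reads amino to acetamido. For the measured compounds named here, no pair of measured compounds isolates this change. Compound 2 also carries the acetamido and sits within the scatter of compound 1, but compound 2 differs from compound 1 in a second place as well, so what the acetyl contributes on its own is not known. The step is expected to be small, none beyond the scatter, a 1.3-fold higher number from compound 1 to compound 3 (0.12 log units; within the scatter). For compound 3 the estimate in this assay is 200 nM, with a range from 70 nM to 600 nM.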

Compound 3, half-maximal effective concentration: 1000 nM
Compound 3: the middle estimate sits 5.0-fold (0.70 log units) below what was measured, and the stated range ends below it.
By their numbers in this assay, from the lowest: compounds 1 and 2 (each within the scatter of the next); then compound 3.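

Acetyl in place of hydrogen on a nitrogen on an aromatic ring is the first change in this series that can be read on its own, and in this assay it gives a 6.7-fold higher number from compound 1 to compound 3 (0.82 log units; beyond the scatter) on the core of compound 1, so at this nitrogen the amino group cannot be swapped for acetamido without a shift in the read-out. The acetamido group alone does not fix the number: in this assay compound 2 also carries it and gives 280 nM while compound 3 gives 1000 nM with the other place on the core differing between them. Nothing at hand gives a reason for the size of this step.

From the compounds shown here alone, whether the step belongs to the carbonyl or to any substituent on this nitrogen stays open, and a methyl or a longer acyl such as propionyl on the same nitrogen would tell the two apart. Also open, going by these compounds, is whether acetyl gives a step of similar size when the ethoxy of compound 1 gives way to a methoxy or a longer alkoxy chain.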